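Paw edema series: compound 3 to the pending compound 4

This account rests on a few compounds, and the source may have more. Where it says the series, first, only, none or still open, it means among the compounds named here.

In a functional assay on the whole organism (strain Sprague-Dawley) for inhibition, with Rattus norvegicus as the target, read by paw edema, with stated times of 1 h and 2 h, at a dose of 70 mg/kg by the subcutaneous route (a higher number here means more inhibition at the dose given (going by the name of the read-out), a lower number less inhibition), compound 1 `Cc1nc2c(c(-c3ccccc3)c(-c3ccccc3)n2-c2c(C)c(=O)n(-c3ccccc3)n2C)c(=O)[nH]1` gives 5.37%, compound 2 `Cc1c(-n2c(N)c(C(N)=O)c(-c3ccccc3)c2-c2ccccc2)n(C)n(-c2ccccc2)c1=O` gives 26.2%, and compound 3 `Cc1c(-n2c(-c3ccccc3)c(-c3ccccc3)c3c(N/N=C/c4ccccc4)ncnc32)n(C)n(-c2ccccc2)c1=O` gives 59.6%. Compound 3 stands highest of the three numbers; compound 2 is the nearest to it and compound 1 the furthest, and both gaps lie beyond the scatter. No pair among these three differs in a single place, so no measured step is at hand to size what a single change does here.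

Compound 4 `Cc1ccccc1Nc1ncnc2c1c(-c1ccccc1)c(-c1ccccc1)n2-c1c(C)c(=O)n(-c2ccccc2)n1C` differs from compound 3 in one place: a group of 7 heavy atoms (7 carbon; one six-membered aromatic ring of carbon only) in place of a group of 8 heavy atoms (7 carbon, 1 nitrogen; one six-membered aromatic ring of carbon only), on a nitrogen on an aromatic ring. Among the compounds with values here, the change is read on its own, with no comparable step among the measured compounds to anchor it. The expectation is a step of a number 14.6 percentage points lower from compound 3 to compound 4 (beyond the scatter) in this assay, downward from compound 3 but of a size that may or may not clear the scatter. Compound 4 is therefore estimated at 45%, within a range from 20% to 70%.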

Compound 4, a percentage reported as inhibition, in the whole organism at one dose (the size of the read-out at that dose, not a potency): 5.17%
Compound 4: middle estimate off by 39.8 percentage points, on the high side; measured number outside the range, below it.
By their numbers in this assay, from the lowest: compounds 4 and 1 (each within the scatter of the next); then compound 2; then compound 3.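

In this assay, the series now has its first measured single-place change: a number 54.4 percentage points lower from compound 3 to compound 4 (beyond the scatter), as 2-methylphenyl enters in place of the group with the double bond outside aromatic rings, on a nitrogen on an aromatic ring. Both groups carry a six-membered aromatic ring of carbon only, so the presence of that ring does not by itself preserve the read-out, and this place is clearly sensitive to what it carries. No measurement shown here accounts for the step.

Still open, from the compounds shown here alone, is which part of the change carries the step: the loss of the nitrogen, the loss of the double bond, or the methyl on the entering ring. Also open, going by these compounds, is where an unsubstituted phenyl or a benzyl group at this place would fall.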